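Thiazole in place of difluorophenyl on a diaryl acid amide

The source may report more compounds than this note shows. Statements on the series, on what has been measured and on what is new or still open speak of the compounds shown alone.

Compound 1 `N=C(NCCCc1c[nH]cn1)NC(=O)CC(c1ccccc1)c1ccccc1`: 28.2 nM
Compound 2 `N=C(NCCCc1c[nH]cn1)NC(=O)CC(c1ccc(F)cc1)c1ccc(F)cc1`: 204 nM
Compound 3 `N=C(NCCCc1c[nH]cn1)NC(=O)CC(c1ccccc1)c1ccc(F)c(F)c1`: 53.7 nM

All three compounds were tested in a functional assay on cardiac atrium for agonist activity at histamine H2 receptor (Cavia porcellus); a higher number here means that more compound is needed for the effect, a lower number that less compound is needed. Compound 3 stands second highest of the three numbers; its nearest neighbour is compound 1, and the step of a 1.9-fold higher number from compound 1 to compound 3 (0.28 log units; within the scatter) is within the scatter, so the two cannot be told apart. Compound 2 sits furthest away, with a higher number than compound 3.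

Compound 4 `N=C(NCCCc1c[nH]cn1)NC(=O)CC(c1ccccc1)c1nccs1` is not yet measured. It differs from compound 3 in one place: 1,3-thiazol-2-yl in place of 3,4-difluorophenyl on a saturated chain carbon bound to an aromatic carbon and a saturated chain carbon. For the measured compounds named here, only one measured step touches this carbon, the step from compound 1 to compound 3, and it was small. Going by the values given here, compound 2, which carries two fluorinated rings, gives a higher number than both, but no single-change step links it to compound 3. Among the compounds with values here, no measured step shows a five-membered ring with hetero atoms at this position, so the expectation rests on the small movement seen so far. The step of a 1.1-fold higher number from compound 3 to compound 4 (0.05 log units; within the scatter) is therefore expected to be small, without a clear direction beyond the scatter. Compound 4 is estimated at 60 nM, with a range from 20 nM to 200 nM in this assay .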

Compound 4, half-maximal effective concentration: 38 nM
The estimate for compound 4 lay 1.6-fold (0.20 log units) above the measured number; the measured number falls inside the stated range.
By their numbers in this assay, from the lowest: compounds 1, 4 and 3 (each within the scatter of the next); then compound 2.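

In this assay, a five-membered aromatic ring with 2 hetero atoms now sits on the saturated chain carbon, and neither step leaves the scatter: a 1.4-fold lower number from compound 3 to compound 4 (0.15 log units; within the scatter), and a 1.3-fold higher number from compound 1 to compound 4 (0.13 log units; within the scatter). For the compounds shown here, this position, so far seen only with phenyl and fluorinated phenyl rings, therefore also tolerates 1,3-thiazol-2-yl, which brings nitrogen and sulfur into the ring, with no change that can be told from the scatter. No evidence is available on why these rings give such similar numbers.

The compounds shown leave open whether a ring bearing an amine or a carboxylic acid at this carbon would move the number beyond the scatter. From the compounds shown here alone, it also remains open whether 1,3-thiazol-2-yl would behave the same way if the remaining phenyl ring were replaced by 4-fluorophenyl.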